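A few compounds are considered here, and "the series" means these few. Any claim that something is new, unique, unknown or untested is made for them only; others in the source may bear on it.

Compound 1 `CCN(CC)c1ccc2cc(C(=O)c3ccc(N4CCN(C(=O)CN5CCN(S(=O)(=O)C6CC6)CC5)CC4)cc3)oc2c1` carries a cyclopropyl on the sulfonyl sulfur; in a functional assay on MCF7 cells (Homo sapiens) for cytotoxicity, read by MTT assay, with a stated time of 48 h (on this read-out lower numbers stand for stronger inhibition and higher numbers for weaker inhibition), compound 1 reaches only the assay limit of > 40000 nM. Compound 2 `CCN(CC)c1ccc2cc(C(=O)c3ccc(N4CCN(C(=O)CN5CCN(S(=O)(=O)c6ccc(C(F)(F)F)cc6)CC5)CC4)cc3)oc2c1`, with 4-(trifluoromethyl)phenyl in its place, gives 17500 nM in this assay, the only number shown in the pair, the step of an at least 2.2-fold lower number from compound 1 to compound 2 (0.35 log units; beyond the scatter) running beyond the scatter. Compound 3 `CCN(CC)c1ccc2cc(C(=O)c3ccc(N4CCN(C(=O)CN5CCN(S(=O)(=O)c6ccc(C#N)cc6)CC5)CC4)cc3)oc2c1` differs by cyano in place of trifluoromethyl on an aromatic carbon. For the measured compounds named here, only the step from compound 1 to compound 2 bears on it, and that step swapped the whole sulfonyl substituent; no measured step exchanges one substituent for another on that ring, so no change beyond the scatter is expected. Compound 3 is therefore expected at 20000 nM, between 8000 nM and 50000 nM, a step of a 1.1-fold higher number from compound 2 to compound 3 (0.06 log units; within the scatter).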

Compound 3, half-maximal inhibitory concentration: > 40000 nM
Compound 3 was reported as a limit (the forecaster's own chance of this, stated with the estimate: 25%); at least 2.0-fold (0.30 log units) between middle value and limit.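

In this assay, the group para to a large group on this aromatic ring matters, not just the presence of an aryl group on the sulfonyl sulfur: cyano in place of trifluoromethyl gives an at least 2.2-fold higher number from compound 2 to compound 3 (0.35 log units; beyond the scatter). The value of compound 3 is a limit, not a number, so the step between compound 1 and compound 3 cannot be read. Only compound 2 gives a number, and the rest of the series sits at a limit: the limit of > 40000 nM in this assay, at which 2 of the 3 values shown sit.

As far as these compounds go, the size of the loss with cyano stays open. Also open, from the compounds shown here alone, is whether a chlorine, a methoxy group or an amine at this place would give a readable value.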